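Benzoyl amide replaces cyclopropylmethyl on the piperidine nitrogen

The compounds below may be only part of what the source reports. "The series", "measured", "known", "first", "only" and "open" are said of these compounds alone.

Measured so far:
compound 1, `O=C(C1CC1)N1CCC(NCCSC(c2ccc(F)cc2)c2ccc(F)cc2)CC1`, with 178 nM in an assay on membranes from striatum (strain Sprague-Dawley) for displacement of a labelled ligand from sodium-dependent dopamine transporter (Rattus norvegicus), read by scintillation counting, with a stated time of 120 min; a lower number here means a stronger inhibitor, a higher number a weaker inhibitor
compound 2, `Fc1ccc(C(SCCNC2CCN(CC3CC3)CC2)c2ccc(F)cc2)cc1`, with 407 nM in this assay

Among the measured compounds shown here, of the two measured compounds, compound 2 gives the higher number in this assay, and the step of a 2.3-fold higher number from compound 1 to compound 2 (0.36 log units; beyond the scatter) is the only measured step. Compound 3, `O=C(c1ccccc1F)N1CCC(NCCSC(c2ccc(F)cc2)c2ccc(F)cc2)CC1`, is not yet measured. The change from compound 2 to compound 3 is (2-fluorophenyl)carbonyl in place of cyclopropylmethyl on an amine nitrogen in a ring. The step from compound 1 to compound 2 bears on it directly, since it removed a carbonyl from the same ring nitrogen and the number rose; compound 3 brings a carbonyl back on that nitrogen, now carrying a 2-fluorophenyl rather than a cyclopropyl. Compound 3 is therefore expected to give a number close to that of compound 1, a modest fall from compound 2 of about a 2.3-fold lower number from compound 2 to compound 3 (0.35 log units; beyond the scatter). The estimate for compound 3 in this assay is 180 nM, within the range 60 nM to 550 nM.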

Compound 3, inhibition constant: 46.1 nM
Beside the measured number, compound 3's estimate is 3.9-fold (0.59 log units) above it, and the stated range ends above it.
By their numbers in this assay, from the lowest: compound 3; then compound 1; then compound 2.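

In this assay, keeping the carbonyl on the ring nitrogen and exchanging only the group it carries gave a 3.9-fold lower number from compound 1 to compound 3 (0.59 log units; beyond the scatter), so the carbonyl alone does not set the number at this position and 2-fluorophenyl on it differs measurably from cyclopropyl. The full exchange of cyclopropylmethyl for (2-fluorophenyl)carbonyl gave an 8.8-fold lower number from compound 2 to compound 3 (0.95 log units; beyond the scatter), which leaves compound 3 with the lowest number of the three, and both of its steps lie beyond the scatter. No measurement offered here accounts for either step.

From the compounds shown here alone, it remains open how a plain benzoyl group would compare with (2-fluorophenyl)carbonyl, a comparison that would separate the fluorine from the phenyl ring. Also open, going by these compounds, is whether the carbonyl still counts with this aryl group present, which a 2-fluorobenzyl group on the same nitrogen would test.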